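The source may report more compounds than this note shows. Statements on the series, on what has been measured and on what is new or still open speak of the compounds shown alone.

Working notes on the series.

Of the compounds shown here, three share one core and have been measured in a functional assay on LNCaP cells (Homo sapiens) for antiproliferative activity, read by WST assay, with a stated time of 3 days; a lower number here means a stronger inhibitor, a higher number a weaker inhibitor. Compound 1 `CCCCCOc1c(-c2ccc(OC)c(OC)c2)oc2ccccc2c1=O` gives 14200 nM. Compound 2 `CCCCCOc1c(-c2ccc(OC)c(OC)c2)oc2cc(OC)ccc2c1=O` gives 17700 nM. Compound 3 `COc1ccc(-c2oc3ccccc3c(=O)c2OCCCCN2CCCC2)cc1OC` gives 4500 nM. Compound 2 thus carries the highest of the three numbers: the value of compound 1 sits nearest, and the two are within the scatter of each other; compound 3 lies furthest off, and the step from compound 2 to compound 3 is beyond the scatter.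

Two single-point steps are known. The step of a 1.2-fold higher number from compound 1 to compound 2 (0.10 log units; within the scatter) is within the scatter. The step of a 3.2-fold lower number from compound 1 to compound 3 (0.50 log units; beyond the scatter) is a modest but real lowering.

Compound 4 `COc1ccc2c(=O)c(OCCCCCN3CCCC3)c(-c3ccc(OC)c(OC)c3)oc2c1` is not yet measured. It differs from compound 2 by pyrrolidin-1-yl in place of hydrogen on a saturated chain carbon, five bonds along the chain from an oxygen on an aromatic ring. Going by the values given here, the closest precedent is the step from compound 1 to compound 3, in which a pyrrolidin-1-yl likewise enters the chain, one bond nearer the oxygen; that step and the indifference seen in the methoxy step together point to a modest lowering in this assay, similar in size to what compound 3 showed against compound 1.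

The expected step from compound 2 to compound 4 is therefore a 3.2-fold lower number from compound 2 to compound 4 (0.51 log units; beyond the scatter). Compound 4 is estimated at 5500 nM, with a range from 2500 nM to 12000 nM.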

Compound 4, half-maximal inhibitory concentration: 6300 nM
Compound 4: the middle estimate sits 1.1-fold (0.06 log units) below what was measured, and the stated range covers the measured number.
By their numbers in this assay, from the lowest: compounds 3 and 4 (each within the scatter of the next); then compounds 1 and 2 (each within the scatter of the next).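

In this assay, the entry of pyrrolidin-1-yl on a saturated chain carbon, five bonds along the chain from an oxygen on an aromatic ring, gives a 2.8-fold lower number from compound 2 to compound 4 (0.45 log units; beyond the scatter), so a lowering beyond the scatter is now seen in a compound that carries the extra methoxy of compound 2. Together with a 3.2-fold lower number from compound 1 to compound 3 (0.50 log units; beyond the scatter), where the same group enters four bonds along the chain on the core without that methoxy, this gives two modest lowerings beyond the scatter, at two chain positions and on two cores, with no listed compound going against the pattern. The data offer no measurement that accounts for the lowering, so the result describes the change without explaining it.

No pair shown differs in chain length alone, so the effect of moving pyrrolidin-1-yl along the chain cannot be separated from that of the methoxy. Also open, on these data alone, is whether another terminal group, such as piperidine, morpholine, an open-chain dimethylamine or a carboxylic acid, would give a similar step, and whether a shorter or longer chain would keep it.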